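A few compounds are considered here, and "the series" means these few. Any claim that something is new, unique, unknown or untested is made for them only; others in the source may bear on it.

Compound 1 `CC1=NN(c2ccc(C)cc2)C(=O)C12C=CC(=O)C=C2c1cccc(C)c1` and compound 2 `CC1=NN(c2ccc(Cl)cc2)C(=O)C12C=CC(=O)C=C2c1cccc(C)c1` share one core and differ only in the aryl group on the amide-type nitrogen in a ring. In a functional assay on A549 cells (Homo sapiens) for antiproliferative activity, read by CCK-8 assay, with a stated time of 72 h (on this read-out higher numbers stand for weaker inhibition and lower numbers for stronger inhibition), compound 1 gives 22500 nM, and compound 2 gives 38400 nM. Within the data shown here, the single measured step, a 1.7-fold higher number from compound 1 to compound 2 (0.23 log units; within the scatter), leaves the two compounds within the scatter of each other, so compound 2 cannot be set apart from compound 1 on the numbers so far, even though its number is the one recorded for the present step.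

Compound 3 `CC1=NN(c2cccc(Cl)c2)C(=O)C12C=CC(=O)C=C2c1cccc(C)c1` is the next member. Its change from compound 2 is 3-chlorophenyl in place of 4-chlorophenyl on an amide-type nitrogen in a ring. Among the measured compounds shown here, no measured step bears on a shift of the chloro within that ring: the step from compound 1 to compound 2 exchanged methyl for chloro in the same place and stayed within the scatter, and nothing recorded speaks to where on the ring the chloro sits. With no evidence pointing either way, the step is expected to be a 1.1-fold lower number from compound 2 to compound 3 (0.05 log units; within the scatter), not beyond the scatter. Compound 3 is therefore estimated at 34000 nM in this assay, with a range from 12000 nM to 95000 nM.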

Compound 3, half-maximal inhibitory concentration: 20100 nM
The estimate for compound 3 lay 1.7-fold (0.23 log units) above the measured number; measured number inside the range.
By their numbers in this assay, from the lowest: compounds 3, 1 and 2 (each within the scatter of the next).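

Moving the chloro, with 3-chlorophenyl in place of 4-chlorophenyl, gives a 1.9-fold lower number from compound 2 to compound 3 (0.28 log units; within the scatter) in this assay. Among these compounds, this is the first reading of where a substituent sits on this aryl group, and on these numbers the placement of the chloro cannot be separated from the scatter. The exchange of 4-methylphenyl for 3-chlorophenyl, which alters both the group and its place on the ring, gives a 1.1-fold lower number from compound 1 to compound 3 (0.05 log units; within the scatter) and so allows no ranking among the three aryl groups on the amide-type nitrogen in a ring; no available evidence bears on these values.

Still open, on these data alone, is whether a group of another kind on this phenyl ring, such as a methoxy group, an amine or a carboxylic acid, would move the number beyond the scatter in this assay. The methyl group and the second aryl group on the shared core are the same in all three compounds, so the compounds shown say nothing about what changes there would do.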